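Working notes: ring substitution and antiproliferative activity

This account rests on a few compounds, and the source may have more. Where it says the series, first, only, none or still open, it means among the compounds named here.

Measured compounds:
compound 1 `COc1ccc(/C=C/S(=O)(=O)Cc2ccc(OC)cc2)cc1` — > 20000 nM
compound 2 `COc1ccc(CS(=O)(=O)/C=C/c2ccc(F)cc2)cc1` — 2500 nM
compound 3 `COc1ccc(CS(=O)(=O)/C=C/c2ccc(F)cc2OC)cc1` — 20000 nM

All three were run in a functional assay on H157 cells (Homo sapiens) for antiproliferative activity, read by trypan blue exclusion; a higher number here means a weaker inhibitor, a lower number a stronger inhibitor. For compound 1 the result > 20000 nM is a limit of the assay, not a number. Compound 2 gives 2500 nM in this assay. Compound 3 gives 20000 nM in this assay.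

The cores of compound 1 and compound 2 differ by methoxy in place of fluoro on an aromatic carbon. In this assay the step is an at least 8.0-fold lower number from compound 1 to compound 2 (0.90 log units; beyond the scatter). The next step is an 8.0-fold higher number from compound 2 to compound 3 (0.90 log units; beyond the scatter), the change being (methoxy in place of hydrogen on an aromatic carbon).

Compound 4 `COc1ccc(CS(=O)(=O)/C=C/c2ccc(OC)c(OC)c2)cc1` has not been measured. It differs from compound 1 by methoxy in place of hydrogen on an aromatic carbon. This is the same kind of change as that from compound 2 to compound 3, not the same one: in compound 3 the entering methoxy sits ortho to a large group and meta to a fluoro group, whereas in compound 4 it sits ortho to a methoxy group and meta to a large group.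

For compound 4 the expected step in this assay is a step that the limit leaves unreadable from compound 1 to compound 4, resting on the measured step of an 8.0-fold higher number from compound 2 to compound 3 (0.90 log units; beyond the scatter) and on compound 1 already sitting at the limit of > 20000 nM in this assay, at which 1 of the 3 values shown sits. Compound 4 is therefore estimated at 60000 nM in this assay, most likely reported only as a limit, with a range of 20000 nM to 200000 nM.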

Compound 4, half-maximal inhibitory concentration: > 20000 nM
Compound 4: a limit, no number; the forecaster's own chance of this, stated with the estimate: 85%; the middle value lies beyond the limit too.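

In this assay compound 4 gives > 20000 nM, a limit of the assay and not a number. Compound 1 also stands at a limit, so no step from compound 1 to compound 4 can be read: the limit of > 20000 nM in this assay, at which 2 of the 4 values shown sit.

The compounds shown leave open whether methoxy in place of hydrogen on an aromatic carbon changes antiproliferative activity at all when the starting compound already sits at the limit, as compound 1 does.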